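Compound 2 to compound 3: a larger group on the amine

The source may hold more compounds than are shown below. What is called first, only, known or untested is meant among the compounds shown, and "the series" means these compounds.

In a functional assay on VCaP cells (Homo sapiens) for antiproliferative activity, read by CCK-8 assay, with a stated time of 6 days (on this read-out lower numbers stand for stronger inhibition and higher numbers for weaker inhibition), compound 1 (`C[C@@H](Cn1ccc(-c2ccc(C#N)c(Cl)c2)n1)NS(=O)(=O)c1cccnc1`) gives 2450 nM. Compound 2 (`C[C@@H](Cn1ccc(-c2ccc(C#N)c(Cl)c2)n1)Nc1cccnc1`) gives > 30000 nM in this assay, which is a limit of the assay and not a number. Compound 2 therefore has no measured position in the series, only this limit.

Compound 3 (`C[C@@H](Cn1ccc(-c2ccc(C#N)c(Cl)c2)n1)Nc1ncnc2nc[nH]c12`) keeps the shared core and changes only the group on the amine nitrogen: a group of 9 heavy atoms (5 carbon, 4 nitrogen; one five-membered aromatic ring with 2 hetero atoms, one six-membered aromatic ring with 2 hetero atoms) in place of a group of 6 heavy atoms (5 carbon, 1 nitrogen; one six-membered aromatic ring with 1 hetero atom), on an amine nitrogen.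

Among the compounds with values here, one measured step bears on this place, an at least 12-fold higher number from compound 1 to compound 2 (1.08 log units; beyond the scatter). It is large and beyond the scatter. This single step shows that the read-out can respond strongly to a change at this nitrogen, but the group entering in compound 3 is a different one, so the support is indirect.

The expected change is towards stronger inhibition, of moderate size, and compound 3 could also remain at the limit. The estimated step is an at least 3.7-fold lower number from compound 2 to compound 3 (0.57 log units; beyond the scatter). For compound 3 the expected value is 8000 nM, with an estimated range of 1500 nM to 30000 nM.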

Compound 3, half-maximal inhibitory concentration: 640 nM
Estimate against measurement, compound 3: 13-fold (1.10 log units) above; the whole stated range lies above it.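

In this assay the sulfonyl link is not required for activity at this amine nitrogen: with a group of one five-membered and one six-membered aromatic ring attached without that link, the series shows an at least 46-fold lower number from compound 2 to compound 3 (1.67 log units; beyond the scatter). The size of that step is only a bound, as the value of compound 2 is a limit of the assay and not a number: the limit of > 30000 nM in this assay, at which 1 of the 3 values shown sits. The new group also improves on the sulfonamide, with a 3.8-fold lower number from compound 1 to compound 3 (0.58 log units; beyond the scatter), a modest but real step that gives compound 3 the lowest number of the three, so the loss seen with pyridin-3-yl does not extend to every aromatic group placed directly on this nitrogen.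

Which feature of the entering group carries the gain stays open, since the second ring, the extra ring nitrogens and the hydrogen-bond donor all change together in these compounds. A single pyrimidine ring on the same amine nitrogen, or a methyl group on the nitrogen-bearing hydrogen of the five-membered ring, would begin to separate these features.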